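The compounds below may be only part of what the source reports. "The series", "measured", "known", "first", "only" and "open" are said of these compounds alone.

Measured in a functional assay on SW480 cells (Homo sapiens) for cytotoxicity, read by MTT assay, with a stated time of 48 h; on this read-out lower numbers stand for stronger inhibition and higher numbers for weaker inhibition:
compound 1 `COc1cc([C@@H]2C[C@@]2(CO)C(=O)Nc2ccccc2)cc(OC)c1OC`: 76800 nM
compound 2 `COc1cc([C@@H]2C[C@]2(CO)C(=O)NCc2ccc(C)cc2)cc(OC)c1OC`: 26800 nM
compound 3 `COc1cc([C@H]2C[C@]2(CO)C(=O)Nc2ccccc2)cc(OC)c1OC`: > 100000 nM

Compound 3 sits at the limit of > 100000 nM in this assay, at which 1 of the 3 values shown sits, so it has a limit and not a number. Compound 4 `COc1cc([C@@H]2C[C@]2(CO)C(=O)Nc2ccccc2)cc(OC)c1OC` relates to compound 3 as follows: the two compounds have the same atoms and bonds and differ only in configuration as drawn: 1 of 2 stereo elements differ; a stereocentre at a saturated ring carbon is drawn R in compound 3 and S in compound 4. Among the measured compounds shown here, the one measured step that bears on this is an at least 1.3-fold higher number from compound 1 to compound 3 (0.11 log units; that floor lies within the scatter), and the fact that compounds 1 and 3 differ only in the configuration as drawn describes that pair. That step inverts both stereo elements and gives only a floor, so it fixes no size for a change at one stereocentre. Compound 1, at 76800 nM, offers the nearest number. A modest move toward a lower number is expected, estimated as an at least 1.6-fold lower number from compound 3 to compound 4 (0.22 log units; that floor lies within the scatter). The estimated value for compound 4 is 60000 nM, with an expected range of 25000 nM to 100000 nM.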

Compound 4, half-maximal inhibitory concentration: 33300 nM
Compound 4: middle estimate off by 1.8-fold (0.26 log units), on the high side; low and high end bracket the measured number.
By their numbers in this assay, from the lowest: compounds 2 and 4 (each within the scatter of the next); then compound 1. At a limit, above all of these: compound 3.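

In this assay compound 3 gives only a limit, > 100000 nM. A single stereocentre still moves the number beyond the scatter, with an at least 3.0-fold lower number from compound 3 to compound 4 (0.47 log units; beyond the scatter) and, at the other stereocentre, with a 2.3-fold lower number from compound 1 to compound 4 (0.36 log units; beyond the scatter), so each of the two stereocentres counts on its own. With a 1.2-fold higher number from compound 2 to compound 4 (0.09 log units; within the scatter), phenyl and 4-methylbenzyl on the amide-type nitrogen are not told apart in this configuration. The compounds shown leave open whether the same dependence on configuration holds with 4-methylbenzyl, and whether an amine or a longer chain on that nitrogen would lower the number.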